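This account rests on a few compounds, and the source may have more. Where it says the series, first, only, none or still open, it means among the compounds named here.

The three measured compounds and their values in a functional assay on L02 cells (Homo sapiens) for inhibition, read by MTT assay, with a stated time of 72 h; a higher number here means a weaker inhibitor, a lower number a stronger inhibitor:

Compound 1, `C=C(c1ccc(OC)c(F)c1)C1COC2(CCCC2)OO1`, gives 18500 nM.
Compound 2, `C=C(c1ccc(F)c(F)c1)C1COC2(CCCC2)OO1`, gives 8840 nM.
Compound 3, `C=C(c1ccc(F)c(F)c1)C1COC2(CCCCC2)OO1`, gives 16500 nM.

Compound 1 and compound 2 share one core and differ only in methoxy in place of fluoro on an aromatic carbon. That change produced a 2.1-fold higher number from compound 2 to compound 1 (0.32 log units; beyond the scatter) in this assay. Compound 3 carries a different core; the difference between the two cores is not broken down here. Its value and that of compound 1 lie within the scatter of each other, as do its value and that of compound 2.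

Compound 4, `C=C(c1ccc(OC)c(F)c1)C1COC2(CCCCC2)OO1`, has not yet been measured. It differs from compound 3 in methoxy in place of fluoro on an aromatic carbon, the same change that turned compound 2 into compound 1, made at the same kind of place. If the step behaves as it did there, compound 4 is expected to show a 2.0-fold higher number from compound 3 to compound 4 (0.30 log units; within the scatter) in this assay, resting on compound 3 at 16500 nM and on the earlier step of a 2.1-fold higher number from compound 2 to compound 1 (0.32 log units; beyond the scatter). With that, compound 4 is estimated at 33000 nM, likely between 16000 nM and 70000 nM.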

Compound 4, half-maximal inhibitory concentration: 15400 nM
Beside the measured number, compound 4's estimate is 2.1-fold (0.33 log units) above it; measured number below the stated range.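

On the core of compound 3, putting methoxy in place of fluoro gave a 1.1-fold lower number from compound 3 to compound 4 (0.03 log units; within the scatter) in this assay, so the clear step seen on the core of compound 1 does not reappear as a clear step here. Set side by side, however, the two results are not far enough apart to count as a real difference between the cores: the same change on two cores in this assay, a 2.1-fold higher number (0.32 log units; beyond the scatter) from compound 2 to compound 1 and a 1.1-fold lower number (0.03 log units; within the scatter) from compound 3 to compound 4, 2.2-fold (0.35 log units) apart, within the scatter of two such steps

This means the data show neither that the change carries over unchanged from one core to the other nor that the core alters its effect, since a single pair on each core cannot separate a small true effect from ordinary scatter.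

Going by these compounds, only fluoro and methoxy appear at this place on the aromatic ring, so it remains open how an amine, a carboxylic acid or a longer chain such as ethoxy would behave there. It also remains open whether these small steps would hold on any core beyond the two shown.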